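The source may hold more compounds than are shown below. What is called first, only, known or untested is meant among the compounds shown, and "the series" means these compounds.

Measured compounds:
compound 1 `Cc1ccnc(NC[C@@H]2CC3(CC3)CN2C(=O)c2nc(C)sc2-c2ccccc2)n1` with 6.1
compound 2 `Cc1ccc(-n2nccn2)c(C(=O)N2CC3(CC3)C[C@H]2CNc2ccc(Cl)cn2)c1` with 8.1
compound 3 `Cc1ccc(-c2ncccn2)c(C(=O)N2CC3(CC3)C[C@H]2CNc2ccc(Cl)cn2)c1` with 8.2

In a functional assay on CHO cells for antagonist activity at Orexin/Hypocretin receptor type 1 (Homo sapiens), read by FLIPR and calcium flux (a higher number here means a more potent compound, by a factor of ten per unit of this negative logarithm, a lower number a less potent compound), compound 1 stands lowest of the three measured numbers; compound 2 and compound 3 lie far above it, beyond the scatter. Among the measured compounds shown here, the one measured step, a number 0.10 log units higher from compound 2 to compound 3 (within the scatter), changes a group on an aromatic carbon of the amide side and lies within the scatter. Compound 4 `Cc1cc(C(F)(F)F)cc(NC[C@@H]2CC3(CC3)CN2C(=O)c2nc(C)sc2-c2ccccc2)n1` differs from compound 1 elsewhere: 6-methyl-4-(trifluoromethyl)pyridin-2-yl in place of 4-methylpyrimidin-2-yl on an amine nitrogen. No measured step touches the group on the amine nitrogen, so the direction of this change has no direct precedent among these compounds. A moderate rise is guessed, with wide uncertainty: compound 4 is expected at 7, between 6 and 8, a step of a number 0.90 log units higher from compound 1 to compound 4 (beyond the scatter) from compound 1.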

Compound 4, negative logarithm of the antagonist equilibrium constant: 7.8
Beside the measured number, compound 4's estimate is 0.80 log units below it, within the range that was stated.
By their numbers in this assay, from the lowest: compound 1; then compounds 4, 2 and 3 (each within the scatter of the next, the first and the last beyond it).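

In this assay, the group on the amine nitrogen turns out to matter greatly: replacing 4-methylpyrimidin-2-yl with 6-methyl-4-(trifluoromethyl)pyridin-2-yl gives a number 1.70 log units higher from compound 1 to compound 4 (beyond the scatter). This position can therefore shift potency well beyond the scatter, whereas the earlier step, on the amide side, did not. Nothing available explains the rise.

The swap changes the ring's hetero atoms and adds trifluoromethyl at once, so the source of the gain remains unresolved. On these data alone, whether a simpler group such as 6-methylpyridin-2-yl or 4-(trifluoromethyl)pyridin-2-yl on that nitrogen would give a similar number stays open.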